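A few compounds are considered here, and "the series" means these few. Any claim that something is new, unique, unknown or untested is made for them only; others in the source may bear on it.

In a functional assay on A549 cells (Homo sapiens) for antiproliferative activity, read by MTT assay, with a stated time of 48 h (on this read-out lower numbers stand for stronger inhibition and higher numbers for weaker inhibition), compound 1 `Cc1c(Cc2ccccc2)c(=O)oc2cc(OCCOc3no[n+]([O-])c3S(=O)(=O)c3ccccc3)ccc12` gives 2 nM, compound 2 `COc1cc(OCCOc2no[n+]([O-])c2S(=O)(=O)c2ccccc2)ccc1C(=O)/C=C/c1ccc(F)cc1` gives 3.5 nM and compound 3 `Cc1c(Cc2ccc(F)cc2)c(=O)oc2cc(OCCOc3no[n+]([O-])c3S(=O)(=O)c3ccccc3)ccc12` gives 3.7 nM. These three values lie within the usual scatter of one another, so compound 3 has no clear rank among them.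

The next compound, compound 4 `CNS(=O)(=O)Nc1cccc(Cc2c(C)c3ccc(OCCOc4no[n+]([O-])c4S(=O)(=O)c4ccccc4)cc3oc2=O)c1`, keeps the core of compound 3 and changes it in one place: 3-((methylsulfamoyl)amino)phenyl in place of 4-fluorophenyl on a saturated chain carbon bound to an aromatic carbon. The swap happens on a saturated chain carbon bound to an aromatic carbon.

Within the data shown here, only one measured step touches this aromatic ring: a 1.9-fold higher number from compound 1 to compound 3 (0.27 log units; within the scatter), which comes from fluoro in place of hydrogen on an aromatic carbon. Among the measured compounds shown here, that step is small, and it says little about the 3-((methylsulfamoyl)amino)phenyl group, which no measured compound carries. The data therefore point to no clear direction, and no shift beyond the scatter is expected, although the uncertainty is wide.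

The expected step is a 1.4-fold higher number from compound 3 to compound 4 (0.13 log units; within the scatter). For compound 4, the estimated value is 5 nM, with an expected range of 1.2 nM to 25 nM.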

Compound 4, half-maximal inhibitory concentration: 7.9 nM
Beside the measured number, compound 4's estimate is 1.6-fold (0.20 log units) below it; low and high end bracket the measured number.
By their numbers in this assay, from the lowest: compounds 1, 2 and 3 (each within the scatter of the next); then compound 4.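

Until now, this aromatic ring had shown only a change within the scatter, but in this assay the larger group gives a step beyond it: a 2.1-fold higher number from compound 3 to compound 4 (0.33 log units; beyond the scatter). Measured against the unsubstituted parent, adding the (methylsulfamoyl)amino group on an aromatic carbon gives a 4.0-fold higher number from compound 1 to compound 4 (0.60 log units; beyond the scatter), so the position responds to this change, though both steps are only modest and compound 4 still gives 7.9 nM. Nothing measured here accounts for the rise.

As far as these compounds go, what remains open is whether the whole (methylsulfamoyl)amino group matters or only part of it. A plain amine or a carboxylic acid in its place would help to separate these possibilities and show how much this position can accept.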